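The source may hold more compounds than are shown below. What is called first, only, known or untested is meant among the compounds shown, and "the series" means these compounds.

Measured in a functional assay on HeLa cells (Homo sapiens) for inhibition, read by CCK-8 assay, with a stated time of 72 h, tested at 8 uM; a higher number here means more inhibition of growth at the concentration tested, a lower number less inhibition of growth:
- compound 1 `COc1ccc(SCc2ccc(C(=O)Nc3ccccc3N)cc2)cc1`: 79.7%
- compound 2 `CCc1ccc(SCc2ccc(C(=O)Nc3ccccc3N)cc2)cc1`: 71%

Compound 1 holds the higher of these two numbers, but compound 2 lies within the scatter of it, so the pair cannot truly be ranked. Compound 3 `COc1ccc(SCc2ccc(C(=O)Nc3ccccc3N)cc2)cc1OC` keeps the core of compound 1 and adds one group: methoxy in place of hydrogen on an aromatic carbon. For the measured compounds named here, only one measured step bears on this, and only loosely, since it swaps a methoxy rather than adding one: a number 8.7 percentage points lower from compound 1 to compound 2 (within the scatter). That small step gives no reason to expect a real shift in this assay. The expected change is a number 4.7 percentage points lower from compound 1 to compound 3 (within the scatter), which would stay within the scatter. For compound 3 the estimated value is 75%, with an expected range of 60% to 88%.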

Compound 3, percent growth inhibition at one concentration: 79.9%
Estimate against measurement, compound 3: 4.9 percentage points below, within the range that was stated.
By their numbers in this assay, from the lowest: compounds 2, 1 and 3 (each within the scatter of the next).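

In this assay, methoxy in place of hydrogen, ortho to a methoxy group, gives a number 0.2 percentage points higher from compound 1 to compound 3 (within the scatter), so this position accepts the added group with no readable shift in growth inhibition. The earlier pair only exchanged one group for another, whereas this step adds a group to the ring and shows that the extra methoxy leaves the number within the scatter. The data shown offer no measurement that could explain this result. On these data alone, whether an amine, a carboxylic acid or a longer chain such as butoxy at this same position would also leave the number in place remains open.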